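Moving a Thioamide Arm Along the Chain

The source may report more compounds than this note shows. Statements on the series, on what has been measured and on what is new or still open speak of the compounds shown alone.

The measured compounds and their numbers:

Compound 1, `N=C(S)CCn1ncccc1=S`, gives 50%.
Compound 2, `CC/N=C(\S)CCn1nc(-c2ccccc2)ccc1=O`, gives 50.3%.
Compound 3, `Cc1ccc(=O)n(CC(C)C(=N)S)n1`, gives 30.2%.

All three were tested in a functional assay on the whole organism (stomach) for inhibition, with Rattus norvegicus as the target, at a dose of 100 mg/kg by the intraduodenal route; a lower number here means less inhibition, a higher number more inhibition at the dose given (going by the name of the read-out). Among them compound 2 stands at the upper end of the numbers seen: the number for compound 1 lies within the usual scatter of its own, so the two cannot be told apart, while the number for compound 3 lies well beyond that scatter, clearly lower than compound 2.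

The next compound, compound 4, `N=C(S)CCCCn1nc(-c2ccccc2)ccc1=O`, has not yet been measured. It is built from the same atoms as compound 2, joined differently: a group of 5 heavy atoms (3 carbon, 1 nitrogen, 1 sulfur; no ring) in place of a group of 5 heavy atoms (3 carbon, 1 nitrogen, 1 sulfur; no ring), on a saturated chain carbon, two bonds along the chain from an aromatic nitrogen.

Going by the values given here, no pair of measured compounds differs in just this way, so the size of the step has to be guessed from what the three numbers show. Compound 1, which also carries a free thioamide on a short chain from the shared core, sits near compound 2, while compound 3 sits lower. The step from compound 2 to compound 4 is therefore expected to be small, most likely downward but not clearly beyond the scatter, and the expected step is estimated as a number 8.3 percentage points lower from compound 2 to compound 4 (within the scatter).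

Compound 4 is expected to give about 42% in this assay, within a range from 25% to 60%.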

Compound 4, a percentage reported as inhibition, in the whole organism at one dose (the size of the read-out at that dose, not a potency): 33.8%
Estimate against measurement, compound 4: 8.2 percentage points above; the measured number falls inside the stated range.
By their numbers in this assay, from the lowest: compounds 3 and 4 (each within the scatter of the next); then compounds 1 and 2 (each within the scatter of the next).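

In this assay, this position responds to how the atoms are joined: the change shows a number 16.5 percentage points lower from compound 2 to compound 4 (beyond the scatter). This is the only pair shown that differs in one place, so it gives the first direct reading of this position, which the earlier compounds could only hint at. The two groups have the same heavy atoms, a group of 5 heavy atoms (3 carbon, 1 nitrogen, 1 sulfur; no ring), yet the number still moves, so the atom count of the group alone does not set the result here; what the count under the two groups does separate is 1 hydrogen-bond donor in the group that leaves and 2 hydrogen-bond donors in the group that enters. Nothing measured here tells why the number moves with this change.

A single pair cannot show whether a longer chain, or an amine or a carboxylic acid in place of the thioamide, would lower the number further or restore it. It also leaves open whether the same rearrangement on the core of compound 1 or compound 3 would give a step of similar size.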